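Pyrrolidinyl for Phenyl: Cytotoxicity Expectation for Compound 4

The source may report more compounds than this note shows. Statements on the series, on what has been measured and on what is new or still open speak of the compounds shown alone.

Of the compounds shown here, three have been measured so far.
Compound 1 `Nc1cc(-c2ccccc2)ccc1Cn1cncc1CNc1ccc(Cl)c(-c2ccccc2)c1` in a toxicity assay on NIH3T3 cells (Mus musculus) for cytotoxicity, read by resazurin assay (on this read-out higher numbers stand for an effect only at larger amounts of compound and lower numbers for an effect already at smaller amounts), gives only a limit of the assay, > 1000 nM.
Compound 2 `Clc1ccc(Cn2cncc2CNc2cccc(-c3ccccc3)c2)cc1` in this assay gives 10000 nM.
Compound 3 `c1ccc(-c2ccc(Cn3cncc3CNc3ccc(-c4ccccc4)c(-c4ccccc4)c3)cc2)cc1` in this assay gives only a limit of the assay, > 10000 nM.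

Compound 3 therefore stands at the limit of > 10000 nM in this assay, at which 1 of the 3 values shown sits, with no number behind it. Compound 1 sits at the limit of > 1000 nM in this assay, at which 1 of the 3 values shown sits, also a limit. Going by the values given here, no two measured compounds differ in only one place, so no single measured step guides the next move. Compound 4 `c1ccc(-c2ccc(Cn3cncc3CNc3ccc(N4CCCC4)c(-c4ccccc4)c3)cc2)cc1` differs from compound 3 by pyrrolidin-1-yl in place of phenyl on an aromatic carbon. Since compound 3 gives only a limit, > 10000 nM, the change can only be read as moving the number downward or leaving it at the limit. Among the compounds with values here, nothing among the measured compounds points to a shift beyond the scatter. The step of a number no higher from compound 3 to compound 4 (the limit leaves the size open) is expected to be small, within the scatter. For compound 4 a value of 10000 nM is estimated, expected between 5000 nM and 30000 nM, most likely again reported only as a limit.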

Compound 4, half-maximal effective concentration: > 1000 nM
Compound 4 was reported as a limit; the forecaster's own chance of this, stated with the estimate: 70%; the middle value does not contradict the limit.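

Compound 3 and compound 4 both stand only as limits in this assay, and the step between them cannot be read. The compounds shown leave open whether pyrrolidin-1-yl in place of phenyl on an aromatic carbon changes the cytotoxicity at all, in which direction, and by how much.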